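Acetoxy to methoxy on the series core

The source may hold more compounds than are shown below. What is called first, only, known or untested is meant among the compounds shown, and "the series" means these compounds.

Measured in a functional assay on SK-BR-3 cells (Homo sapiens) for cytotoxicity, read by MTT assay, with a stated time of 72 h; on this read-out lower numbers stand for an effect already at smaller amounts and higher numbers for an effect only at larger amounts of compound:
Compound 1 `CCOC(=O)c1c(C)coc1-c1ccc2c(CC)cccc2c1OC` gives 2.5 ug/mL
Compound 2 `CCc1cccc2c(OC(C)=O)c(-c3occ(C)c3COC(C)=O)ccc12` gives > 10 ug/mL

Compound 2 stands at > 10 ug/mL, which is a limit of the assay and not a number. Compound 3 `CCc1cccc2c(OC)c(-c3occ(C)c3COC(C)=O)ccc12` differs from it by methyl in place of acetyl on an oxygen on an aromatic ring, with methyl in place of acetyl on an oxygen on an aromatic ring. For the measured compounds named here, no measured step covers this change. Going by the values given here, the only numeric reading in this assay is compound 1 at 2.5 ug/mL. The expected change is an at least 2.0-fold lower number from compound 2 to compound 3 (0.30 log units; that floor lies within the scatter), towards lower numbers. For compound 3 the estimated value is 5 ug/mL, with an expected range of 1.5 ug/mL to 10 ug/mL.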

Compound 3, concentration for half-maximal effect: > 10 ug/mL
Compound 3: only a limit was reported (the forecaster's own chance of this, stated with the estimate: 25%); at least 2.0-fold (0.30 log units) between middle value and limit.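

In this assay, acetoxymethyl in place of ethoxycarbonyl on an aromatic carbon now gives a readable step with the methoxy kept: an at least 4.0-fold higher number from compound 1 to compound 3 (0.60 log units; beyond the scatter). In this pair, the ethoxycarbonyl compound holds the lower number. The step from acetoxy to methoxy cannot be read, because both compounds end at a limit: the limit of > 10 ug/mL in this assay, at which 2 of the 3 values shown sit.

From the compounds shown here alone, it remains open whether acetoxy and methoxy differ when ethoxycarbonyl is present. Also open, going by these compounds, is whether a hydroxyl on that oxygen, or a carboxylic acid or hydroxymethyl on that aromatic carbon, would give a numeric reading.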